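The source may hold more compounds than are shown below. What is called first, only, known or untested is meant among the compounds shown, and "the series" means these compounds.

Of the compounds shown here, two have been measured in a functional assay on the whole organism (strain Wistar albino) for inhibition, with Rattus norvegicus as the target, read by paw edema, with stated times of 30 min and 2 h, at a dose of 20 mg/kg by the oral route; on this read-out higher numbers stand for more inhibition at the one dose given (going by the name of the read-out) and lower numbers for less inhibition. Compound 1, `CC(C)Cc1ccc(C(C)C2=NNC(S)N2N)cc1`, gives 45% in this assay. Compound 2, `CC(C)Cc1ccc(C(C)c2nnc(S)n2/N=C/c2ccc(Cl)cc2)cc1`, gives 57% in this assay. On these two numbers compound 2 stands highest, and the gap that separates it from compound 1 lies beyond the usual scatter of this kind of measurement, so the inhibition of compound 2 in this assay reads as higher than that of compound 1.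

Compound 3, `CC(C)Cc1ccc(C(C)c2nnc(S)n2/N=C/c2ccc(Br)cc2)cc1`, has not yet been measured in this assay. It differs from compound 2 in a single place: bromo in place of chloro on an aromatic carbon. Everything else in the molecule is unchanged. Among the measured compounds shown here, no pair of measured compounds differs in only one place, so the effect of any single exchange in this assay remains unknown from the data at hand.

The expectation is that compound 3 stays close to compound 2, with a step of a number 1 percentage points lower from compound 2 to compound 3 (within the scatter), that is, no change beyond the scatter in either direction. The estimate for compound 3 in this assay is 56%, with a range from 42% to 70%.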

Compound 3, a percentage reported as inhibition, in the whole organism at one dose (the size of the read-out at that dose, not a potency): 60%
Compound 3: middle estimate off by 4 percentage points, on the low side; low and high end bracket the measured number.
By their numbers in this assay, from the lowest: compound 1; then compounds 2 and 3 (each within the scatter of the next).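

In this assay, among the compounds shown here, the exchange of chloro for bromo on an aromatic carbon para to a large group gives a number 3 percentage points higher from compound 2 to compound 3 (within the scatter), and this is the first step that isolates a single place in the molecule. It shows that, at the one dose given, this read-out does not separate the 4-chlorophenyl group from the 4-bromophenyl group, so compound 2 and compound 3 count as one level and the two halogens are interchangeable here as far as this single exchange can tell. Nothing at hand offers an explanation for this outcome, and the step stands as an observation only.

As far as these compounds go, two halogens say little about how far this position can be varied, so it remains open whether an amine, a carboxylic acid or a methoxy group at the same carbon, or plain hydrogen there, would keep the read-out at this level or move it beyond the scatter. From the compounds shown here alone, it also remains open whether the same exchange of chloro for bromo would read alike on another carbon of that ring.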